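The compounds below may be only part of what the source reports. "The series", "measured", "known", "first", "only" and "open" are said of these compounds alone.

For the measured compounds named here, compound 2 `CS(=O)(=O)Nc1cccc2c1CCC2c1ncc[nH]1` gives the lowest of the two numbers measured in a functional assay on CHO cells for agonist activity at Alpha-1A adrenergic receptor (Homo sapiens), read by FLIPR and calcium flux (a lower number here means that less compound is needed, a higher number that more compound is needed for the effect), 70 nM; its only neighbour, compound 1 `c1ccc(-c2cccc3c2CCC3c2ncc[nH]2)nc1`, in this assay gives 1150 nM. Compound 3 `Cc1oncc1-c1cccc2c1CCC2c1ncc[nH]1` follows from compound 2 by 5-methyl-1,2-oxazol-4-yl in place of methanesulfonamido on an aromatic carbon. Going by the values given here, the one measured step, a 16-fold lower number from compound 1 to compound 2 (1.22 log units; beyond the scatter), was large and replaced pyridin-2-yl with methanesulfonamido; compound 3 reverses the sense of that exchange, putting a ring back in the same place. A step back toward the number of compound 1 is therefore expected, though the entering ring is not the one that left. The estimated step is a 7.1-fold higher number from compound 2 to compound 3 (0.85 log units; beyond the scatter). Compound 3 is expected at 500 nM, within 150 nM to 2000 nM.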

Compound 3, half-maximal effective concentration: 111 nM
Compound 3: middle estimate off by 4.5-fold (0.65 log units), on the high side; the measured number lies below the stated range.
By their numbers in this assay, from the lowest: compounds 2 and 3 (each within the scatter of the next); then compound 1.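

In this assay, a 1.6-fold higher number from compound 2 to compound 3 (0.20 log units; within the scatter) separates the two groups at this aromatic carbon only within the scatter, so the hydrogen-bond donor counted for methanesulfonamido is not required for a number at this level. A ring at this position is not in itself tied to a high number, since a 10-fold lower number from compound 1 to compound 3 (1.02 log units; beyond the scatter) is seen on exchanging one aromatic ring for another. No evidence accounts for this difference between the rings. From the compounds shown here alone, whether an amine or a carboxylic acid here would stay level with compound 2 remains open. Also open, going by these compounds, is whether a phenyl ring would fall nearer to pyridin-2-yl or to 5-methyl-1,2-oxazol-4-yl.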